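The compounds below may be only part of what the source reports. "The series", "measured", "known", "first", "only" and "open" are said of these compounds alone.

Measured so far in a functional assay on A549 cells (Homo sapiens) for cytotoxicity, read by MTT assay, with a stated time of 48 h; on this read-out lower numbers stand for lower solubility and higher numbers for higher solubility:
Compound 1 `COc1ccc(/C=N/NC(=O)c2cc(-c3ccc(Cl)cc3)nn2Cc2ccc(Cl)nc2)cc1` gives 3300 nM.
Compound 2 `O=C(N/N=C/c1ccco1)c1cc(-c2ccc(Cl)cc2)nn1Cc1ccc(Cl)nc1` gives 70000 nM.

Compound 2 holds the higher of the two numbers, set apart from compound 1 by the step of a 21-fold higher number from compound 1 to compound 2 (1.33 log units; beyond the scatter). Compound 3 `COc1ccc(-c2cc(C(=O)N/N=C/c3ccco3)n(Cc3ccc(Cl)nc3)n2)cc1` differs from compound 2 by methoxy in place of chloro on an aromatic carbon. Among the compounds with values here, no measured step bears on this change: the only step recorded alters a different part of the molecule, so it offers no guide to the size or direction here. With nothing to go on beyond compound 2 itself, the expected step of a 1.2-fold lower number from compound 2 to compound 3 (0.07 log units; within the scatter) is taken as small, not clearly beyond the scatter. Compound 3 is therefore estimated at 60000 nM, within a range of 15000 nM to 200000 nM.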

Compound 3, solubility: 30000 nM
For compound 3 the middle estimate is 2.0-fold (0.30 log units) above the measured one; the range from low to high includes it.
By their numbers in this assay, from the lowest: compound 1; then compound 3; then compound 2.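

In this assay the step from 4-chlorophenyl to 4-methoxyphenyl gives a 2.3-fold lower number from compound 2 to compound 3 (0.37 log units; beyond the scatter) and lies beyond the scatter. Within the data shown here, the earlier step altered a different part of the molecule, so this is the first sign that the aromatic carbon carrying chloro also affects the number. Nothing available explains this shift.

As far as these compounds go, what an amine or a carboxylic acid on this aromatic carbon would do remains open. Also open, from the compounds shown here alone, is whether methoxy in place of chloro gives a similar step when 4-methoxyphenyl replaces furan-2-yl.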